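This account rests on a few compounds, and the source may have more. Where it says the series, first, only, none or still open, it means among the compounds named here.

Compound 1 `c1ccc2c(c1)CN[C@@H](CN(CC1CCNCC1)[C@H]1CCCc3cccnc31)C2` gives 65 nM. Compound 2 `c1ccc2c(c1)CN[C@@H](CN(CC[C@H]1CCCNC1)[C@H]1CCCc3cccnc31)C2` gives 16 nM. Compound 3 `c1cnc(CN(CCCN2CCNCC2)[C@H]2CCCc3cccnc32)nc1` gives 4320 nM.

All three compounds share the same saturated core and were tested in a functional assay on CCRF-CEM cells for antagonist activity at C-X-C chemokine receptor type 4 (Homo sapiens), read by calcium flux, with stated times of 25 min and 90 s; on this read-out higher numbers stand for weaker inhibition and lower numbers for stronger inhibition. Compound 3 stands at the highest number of the three, so it is the weakest inhibitor here; compound 1 lies a good deal lower and compound 2 lower still, both differences beyond the scatter.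

Compound 4 `c1cnc2c(c1)CCC[C@@H]2N(CCCN1CCNCC1)Cc1nc2ccccc2s1` is the next compound and differs from compound 3 in one place: 1,3-benzothiazol-2-yl in place of pyrimidin-2-yl on a saturated chain carbon bound to an amine nitrogen.

Going by the values given here, the only measured step, a 4.1-fold lower number from compound 1 to compound 2 (0.61 log units; beyond the scatter), changes a different group on a different chain and so does not bear directly on the move from compound 3 to compound 4. Among the compounds with values here, no measured pair shows what swapping the aromatic group on this chain carbon does. Without a guiding step, compound 4 is expected to land near compound 3, with a wide range; a step of a 1.7-fold lower number from compound 3 to compound 4 (0.24 log units; within the scatter) is estimated. Compound 4 is therefore expected to give about 2500 nM, between 500 nM and 12000 nM.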

Compound 4, half-maximal inhibitory concentration: 1200 nM
Beside the measured number, compound 4's estimate is 2.1-fold (0.32 log units) above it; the range from low to high includes it.
By their numbers in this assay, from the lowest: compound 2; then compound 1; then compound 4; then compound 3.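

Going by these compounds alone, changing the group on a saturated chain carbon bound to an amine nitrogen gives the first measured step at this place: in this assay, 1,3-benzothiazol-2-yl in place of pyrimidin-2-yl gives a 3.6-fold lower number from compound 3 to compound 4 (0.56 log units; beyond the scatter) as a modest gain in inhibition. The aromatic group here therefore affects the read-out, and the larger group, with a five-membered aromatic ring and a six-membered aromatic ring of carbon only, is the better of these two. Nothing available explains this difference.

On these data alone, the change swaps the ring system and brings in sulfur in a single move, so the contribution of each part remains open. A 1,3-benzoxazol-2-yl group, with oxygen in place of sulfur, or a simple phenyl group at this place could help separate them.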